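Trifluoromethyl for bromo on the amine aryl: compound 3

The source may report more compounds than this note shows. Statements on the series, on what has been measured and on what is new or still open speak of the compounds shown alone.

Measured compounds:
compound 1, `CCOC(=O)C1=C(Nc2ccc(Br)cc2)S/C(=C\c2ccc[nH]2)C1=O`, in a functional assay on A549 cells (Homo sapiens) for inhibition, read by MTT assay, with a stated time of 72 h, tested at 10 uM; on this read-out lower numbers stand for less inhibition and higher numbers for more inhibition at the one concentration tested (going by the name of the read-out): < 10%
compound 2, `CCOC(=O)C1=C(Nc2cccc(F)c2)S/C(=C\c2ccc[nH]2)C1=O`, in this assay: < 10%

Compound 1 stands at the floor of this assay: its value of < 10% is a limit of the assay and not a number. Compound 2 likewise returns only a limit, < 10%. Going by the values given here, the one measured step, a step that the two limits leave unreadable from compound 1 to compound 2, is therefore unreadable in size, since the limit of < 10% in this assay, at which 2 of the 2 values shown sit, shows both ends sitting at the same limit.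

Compound 3, `CCOC(=O)C1=C(Nc2ccc(C(F)(F)F)cc2)S/C(=C\c2ccc[nH]2)C1=O`, differs from compound 1 by trifluoromethyl in place of bromo on an aromatic carbon. Among the compounds with values here, no measured step covers this change directly; the only comparison available stays at the limit on both sides, so nothing here points to a move beyond the scatter. Compound 3 is therefore expected to remain at the limit as well. Compound 3 is estimated at 5% in this assay, with a range from 0% to 15%. The expected step that the limit leaves unreadable from compound 1 to compound 3 is essentially none.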

Compound 3, a percentage reported as inhibition, at one concentration (the size of the read-out at that concentration, not a potency): 30.1%
Compound 3: middle estimate off by 25.1 percentage points, on the low side; measured number above the stated range.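

Trifluoromethyl in place of bromo on this aromatic carbon gives, in this assay, a number at least 20.1 percentage points higher from compound 1 to compound 3 (beyond the scatter). Going by these compounds alone, the earlier step between compound 1 and compound 2 cannot be read, so this is the first sign that a change on the amine aryl can register in the read-out at all. Among the compounds shown, compound 3 alone comes away from the limit of the assay: the limit of < 10% in this assay, at which 2 of the 3 values shown sit.

Going by these compounds, whether the rise is particular to trifluoromethyl or would also appear with a nitrile or a methoxy group on the same aromatic carbon stays open. The compounds shown give no cause for the step, and a reading at one concentration in this assay gives no potency for compound 3.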